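Swapping the Amine Substituent: An Expectation for Compound 4

The source may report more compounds than this note shows. Statements on the series, on what has been measured and on what is new or still open speak of the compounds shown alone.

Three compounds sharing one core were measured in a functional assay on PC-3 cells (Homo sapiens) for inhibition, with a stated time of 72 h; a higher number here means a weaker inhibitor, a lower number a stronger inhibitor:

Compound 1 `O=C(Nc1ccccc1)Nc1nc(Sc2c[nH]c3ccccc23)cc(N2CCCC2)n1` gives 14900 nM
Compound 2 `O=C(Nc1ccccc1)Nc1nc(Nc2ccc(Cl)cc2)cc(Sc2c[nH]c3ccccc23)n1` gives 32300 nM
Compound 3 `O=C(Nc1ccccc1)Nc1nc(Sc2c[nH]c3ccccc23)cc(N2CCN(c3ccccn3)CC2)n1` gives 21600 nM

Compound 3 holds the second highest of the three numbers, yet both of its steps, a 1.4-fold higher number from compound 1 to compound 3 (0.16 log units; within the scatter) and a 1.5-fold lower number from compound 2 to compound 3 (0.17 log units; within the scatter), lie within the scatter. Compound 4 `O=C(Nc1ccccc1)Nc1nc(Sc2c[nH]c3ccccc23)cc(N2CCCCC2)n1` differs from compound 3 by piperidin-1-yl in place of 4-(pyridin-2-yl)piperazin-1-yl on an aromatic carbon. Two measured steps alter the same position: a 2.2-fold higher number from compound 1 to compound 2 (0.34 log units; beyond the scatter) was modest, and a 1.4-fold higher number from compound 1 to compound 3 (0.16 log units; within the scatter) stayed within the scatter. Because compound 1, carrying the closely related pyrrolidin-1-yl group, gave 14900 nM, a number near that is expected for compound 4. Compound 4 is therefore expected to give 16000 nM, with a range from 7000 nM to 40000 nM. The expected step of a 1.4-fold lower number from compound 3 to compound 4 (0.13 log units; within the scatter) is estimated to stay within the scatter.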

Compound 4, half-maximal inhibitory concentration: 12100 nM
Compound 4: the middle estimate sits 1.3-fold (0.12 log units) above what was measured, and the stated range covers the measured number.
By their numbers in this assay, from the lowest: compounds 4, 1, 3 and 2 (each within the scatter of the next, the first and the last beyond it).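

In this assay, piperidin-1-yl in place of pyrrolidin-1-yl gives a 1.2-fold lower number from compound 1 to compound 4 (0.09 log units; within the scatter), and in place of the larger 4-(pyridin-2-yl)piperazin-1-yl it gives a 1.8-fold lower number from compound 3 to compound 4 (0.25 log units; within the scatter), so neither change moves the number beyond the scatter. In place of (4-chlorophenyl)amino it gives a 2.7-fold lower number from compound 2 to compound 4 (0.43 log units; beyond the scatter), which sets compound 2 apart from compound 1 and compound 4, though not from compound 3. No evidence at hand accounts for these steps.

Still open, from the compounds shown here alone, is how an open-chain amine such as dimethylamino, or a morpholin-4-yl group, would read at this position.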